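The source may report more compounds than this note shows. Statements on the series, on what has been measured and on what is new or still open speak of the compounds shown alone.

In a functional assay on the whole organism (strain albino) for inhibition, with Rattus norvegicus as the target, read by paw edema, with a stated time of 5 h, at a dose of 0.28 mmol/kg by the oral route (a lower number here means less inhibition, a higher number more inhibition at the dose given (going by the name of the read-out)), compound 1 `C=CCn1c(SCC(=O)c2ccccc2)nnc1-c1ccccc1` gives 66%. Two other compounds share its core and the thioether-linked phenyl ketone or its oxime: compound 2 `COc1ccc(-c2nnc(SC/C(=N/O)c3ccccc3)n2-c2ccccc2)cc1` gives 73% in this assay, and compound 3 `COc1ccc(-c2nnc(SCC(=O)c3ccccc3)n2-c2ccccc2)cc1OC` gives 59%. Compound 1 thus stands second of the three numbers, but its gap to compound 2 and its gap to compound 3 both lie within the usual scatter, so the three read as one level rather than an order. Compound 4 `CCn1c(SCC(=O)c2ccccc2)nnc1-c1ccccc1` differs from compound 1 only by methyl in place of vinyl on a saturated chain carbon bound to an aromatic nitrogen. Among the measured compounds shown here, with no comparable step among the measured compounds, the expected step of a number 3 percentage points lower from compound 1 to compound 4 (within the scatter) is small, none beyond the scatter, in either direction. Compound 4 is therefore estimated at 63% in this assay, between 48% and 78%.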

Compound 4, a percentage reported as inhibition, in the whole organism at one dose (the size of the read-out at that dose, not a potency): 51%
Compound 4: middle estimate off by 12 percentage points, on the high side; the measured number falls inside the stated range.
By their numbers in this assay, from the lowest: compounds 4, 3, 1 and 2 (each within the scatter of the next, the first and the last beyond it).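

With allyl replaced by ethyl, the read-out in this assay shows a number 15 percentage points lower from compound 1 to compound 4 (beyond the scatter), so the group on this saturated chain carbon bound to an aromatic nitrogen does matter to the result. The earlier compounds shown here offered no such single-place comparison. Nothing available explains the step. The change alters chain length and removes the double bond together, so the two cannot be told apart here. From the compounds shown here alone, a propyl chain would separate them, and how an amine or a carboxylic acid at this place would read remains open.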